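Inverting one ring stereocentre on a weak antiproliferative

The source may hold more compounds than are shown below. What is called first, only, known or untested is meant among the compounds shown, and "the series" means these compounds.

Compound 2 `CSc1nc2sncc2n1[C@@H]1O[C@H](CO)[C@@H](O)[C@@H]1O` was tested in a functional assay on L1210 cells (Mus musculus) for antiproliferative activity (a higher number here means a weaker inhibitor, a lower number a stronger inhibitor), where compound 2 gives 11000 nM. Among the three measured compounds it stands second highest: compound 3 `Cc1nsc2c1ncn2[C@@H]1O[C@H](CO)[C@@H](O)[C@H]1O` gives 10000 nM, within the scatter of compound 2, and compound 1 `CSc1nc2sncc2n1[C@H]1C[C@H](O)[C@@H](CO)O1` gives 20000 nM, also within the scatter, the step of a 1.8-fold lower number from compound 1 to compound 2 (0.26 log units; within the scatter) being the only one-place step measured. Compound 4 `CSc1nc2sncc2n1[C@@H]1O[C@H](CO)[C@@H](O)[C@H]1O` differs from compound 2 in configuration alone: the two compounds have the same atoms and bonds and differ only in configuration as drawn: 1 of 4 stereo elements differ; a stereocentre at a saturated ring carbon is drawn S in compound 2 and R in compound 4. For the measured compounds named here, no measured step changes a stereocentre, and the sole measured step stayed within the scatter, so it gives no direction. The expected step is no change at the digits printed from compound 2 to compound 4 (within the scatter), none beyond the scatter. Compound 4 is estimated at 11000 nM, with a range from 4000 nM to 30000 nM.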

Compound 4, half-maximal inhibitory concentration: 8600 nM
For compound 4 the middle estimate is 1.3-fold (0.11 log units) above the measured one, and the stated range covers the measured number.
By their numbers in this assay, from the lowest: compounds 4, 3, 2 and 1 (each within the scatter of the next, the first and the last beyond it).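

In this assay, inverting this saturated ring carbon gives a 1.3-fold lower number from compound 2 to compound 4 (0.11 log units; within the scatter) and so shows no effect of configuration beyond the scatter at this stereocentre. The hydroxy in place of hydrogen on a saturated ring carbon, which stayed within the scatter in the earlier step, gives a 2.3-fold lower number from compound 1 to compound 4 (0.37 log units; beyond the scatter) with the R configuration, a modest step beyond the scatter. The stereochemical comparison is clean, resting on one point: the fact that compounds 2 and 4 differ only in the configuration as drawn. From the compounds shown here alone, whether an amine in place of the hydroxy on that ring carbon would change the number remains open.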